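The source may report more compounds than this note shows. Statements on the series, on what has been measured and on what is new or still open speak of the compounds shown alone.

Of the compounds shown here, two have been measured in an assay on FRT-Jurkat cells for inhibition of nuclear factor NF-kappa-B complex (Homo sapiens), read by flow cytometry, with a stated time of 24 h, tested at 10 uM; on this read-out lower numbers stand for less inhibition and higher numbers for more inhibition at the one concentration tested (going by the name of the read-out). Compound 1 `Cc1ccc(Nc2ccc3c(c2)C(=O)N(C2CCC(=O)NC2=O)C3=O)cc1` gives 5% and thereby stands highest of the two numbers, but only by a margin within the scatter: compound 2 `O=C1CCC(N2C(=O)c3cccc(Nc4ccc(O)cc4)c3C2=O)C(=O)N1` gives 4% in this assay, so the two values show no real difference, and both are small. Compound 3 `CCOC(=O)c1ccc(Nc2ccc3c(c2)C(=O)N(C2CCC(=O)NC2=O)C3=O)cc1` has not yet been measured in this assay. Compared with compound 1 it changes in one place: ethoxycarbonyl in place of methyl on an aromatic carbon. Among the compounds with values here, no pair of measured compounds differs in a single place, so nothing measured bears directly on this change. Given that compound 1 sits at 5% and compound 2 is no different, no step beyond the scatter is expected in either direction; the expected step of a number 1 percentage points higher from compound 1 to compound 3 (within the scatter) lies within the scatter. Compound 3 is estimated at 6%, expected to fall between -6% and 20%.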

Compound 3, a percentage reported as inhibition, at one concentration (the size of the read-out at that concentration, not a potency): 5%
Estimate against measurement, compound 3: 1 percentage points above; measured number inside the range.
By their numbers in this assay, from the lowest: compounds 2, 1 and 3 (each within the scatter of the next).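

In this assay the series now has its first step at a single place: ethoxycarbonyl in place of methyl on an aromatic carbon, para to a large group, gives no change at the digits printed from compound 1 to compound 3 (within the scatter) and so leaves the number within the scatter. At this position, therefore, a much larger group carrying hydrogen-bond acceptors, which methyl lacks, does not separate compound 3 from compound 1 on this read-out. No supporting data on hand explain this result.

Going by these compounds, whether an amine or a carboxylic acid at this same position would move the number beyond the scatter remains open. This one step also says nothing about changes elsewhere on the core of compound 1, or about whether any group here would give a clearly higher number.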